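A few compounds are considered here, and "the series" means these few. Any claim that something is new, unique, unknown or untested is made for them only; others in the source may bear on it.

Measured in a functional assay on HCT-116 cells (Homo sapiens) for cytotoxicity, read by MTT assay, with a stated time of 48 h, in the presence of a further agent that is not named here; a lower number here means that less compound is needed, a higher number that more compound is needed for the effect:
- compound 1 `CCN(CC)c1cc(NC(=O)NNc2cc(-c3ccc(F)cc3)c3cnn(C)c3n2)cc(Cl)n1`: 29400 nM
- compound 2 `Cn1ncc2c(-c3ccc(F)cc3)cc(NNC(=O)Nc3cc(Cl)nc(Cl)c3)nc21`: 8210 nM
- compound 3 `CCCCOc1cc(NC(=O)NNc2cc(-c3ccc(OC)cc3)c3cnn(C)c3n2)cc(Cl)n1`: 36500 nM

Compound 3, at 36500 nM, lies within the scatter of compound 1, at 29400 nM. Compound 2, at 8210 nM, has a lower number than either, by more than the scatter.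

Compound 4 `CCCCOc1cc(NC(=O)NNc2cc(-c3ccc(F)cc3)c3cnn(C)c3n2)cc(Cl)n1` differs from compound 3 in one place, with fluoro in place of methoxy on an aromatic carbon. The same difference reads as 4-methoxyphenyl to 4-fluorophenyl. For the measured compounds named here, no measured pair isolates this change. Going by the values given here, the only measured step, a 3.6-fold lower number from compound 1 to compound 2 (0.55 log units; beyond the scatter), is modest and is a different substitution, chloro in place of diethylamino, so it bears on this change only indirectly. Compound 1 and compound 2 both carry the 4-fluorophenyl group, yet their values differ beyond the scatter, so that group does not fix the value by itself. With no evidence for a direction, no step beyond the scatter is expected. The expected change is a 1.2-fold lower number from compound 3 to compound 4 (0.09 log units; within the scatter). Compound 4 is estimated at 30000 nM, with an expected range of 12000 nM to 70000 nM.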

Compound 4, half-maximal effective concentration: 49400 nM
Beside the measured number, compound 4's estimate is 1.6-fold (0.22 log units) below it; the measured number falls inside the stated range.
By their numbers in this assay, from the lowest: compound 2; then compounds 1, 3 and 4 (each within the scatter of the next).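

In this assay the change from 4-methoxyphenyl to 4-fluorophenyl can now be read directly, with butoxy held constant: a 1.4-fold higher number from compound 3 to compound 4 (0.13 log units; within the scatter) shows that, in this pair, the group on this aromatic carbon does not shift the number beyond the scatter. Among the compounds carrying 4-fluorophenyl, the step that counts lies at the other substituent: a 6.0-fold higher number from compound 2 to compound 4 (0.78 log units; beyond the scatter) is beyond the scatter, whereas a 1.7-fold higher number from compound 1 to compound 4 (0.23 log units; within the scatter) leaves butoxy and diethylamino indistinguishable. No measurement shown here accounts for these steps.

On these data alone, whether methoxy and fluoro also stay level when chloro replaces butoxy remains open. So does what a nitrile or an amine on this aromatic carbon, or a longer chain in place of butoxy, would do to the number.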